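Aryl hydrazone series: removing methoxy groups from the benzylidene

The compounds below may be only part of what the source reports. "The series", "measured", "known", "first", "only" and "open" are said of these compounds alone.

Measured so far in a functional assay on A549 cells (Homo sapiens) for cytotoxicity, read by MTT assay, with a stated time of 72 h; a lower number here means a stronger inhibitor, a higher number a weaker inhibitor:
compound 1 `COc1ccc(OC)c(/C=N/NC(=O)Nc2ccc(Oc3ccnc(-c4nncn4CCN(C)C)c3)c(F)c2)c1` gives 1950 nM
compound 2 `CN(C)CCn1cnnc1-c1cc(Oc2ccc(NC(=O)N/N=C/c3ccc(Cl)cc3)cc2F)ccn1` gives 780 nM
compound 3 `COc1ccc(/C=N/NC(=O)Nc2ccc(Oc3ccnc(-c4nncn4CCN(C)C)c3)c(F)c2)c(OC)c1OC` gives 6680 nM

Compound 3 carries the highest number of the three, with compound 1 its nearest neighbour and compound 2 furthest away. Both steps that reach it are beyond the scatter: a 3.4-fold higher number from compound 1 to compound 3 (0.53 log units; beyond the scatter) and an 8.6-fold higher number from compound 2 to compound 3 (0.93 log units; beyond the scatter). The unmeasured compound 4 `CN(C)CCn1cnnc1-c1cc(Oc2ccc(NC(=O)N/N=C/c3ccccc3)cc2F)ccn1` differs from compound 3 only at the carbon with a double bond to nitrogen: phenyl in place of 2,3,4-trimethoxyphenyl on a carbon with a double bond to nitrogen.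

For the measured compounds named here, two measured steps bear on this change. The first is a 3.4-fold higher number from compound 1 to compound 3 (0.53 log units; beyond the scatter), a modest rise in the direction that moves from a dimethoxy-bearing ring to the trimethoxy-bearing one; read in reverse it is a modest drop. The second is an 8.6-fold higher number from compound 2 to compound 3 (0.93 log units; beyond the scatter), a larger rise in the direction that moves from the 4-chlorophenyl to the trimethoxy-bearing ring; read in reverse it is a larger drop. Compound 4 removes all three methoxy groups but adds no chlorine, so a drop at least as large as the first and probably approaching the second is expected in this assay, with the step estimated as a 5.6-fold lower number from compound 3 to compound 4 (0.75 log units; beyond the scatter). For compound 4 the expected value is 1200 nM, with a range of 500 nM to 3000 nM.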

Compound 4, half-maximal inhibitory concentration: 1860 nM
The estimate for compound 4 lay 1.6-fold (0.19 log units) below the measured number; measured number inside the range.
By their numbers in this assay, from the lowest: compound 2; then compounds 4 and 1 (each within the scatter of the next); then compound 3.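

In this assay, phenyl gives this position a reference without substituents, and the two methoxy-bearing rings do not sit alike against it: 2,3,4-trimethoxyphenyl gives way to phenyl with a clear fall (a 3.6-fold lower number from compound 3 to compound 4 (0.56 log units; beyond the scatter)), whereas phenyl and 2,5-dimethoxyphenyl cannot be told apart (a 1.0-fold lower number from compound 1 to compound 4 (0.02 log units; within the scatter)), so the number does not simply follow the presence of methoxy groups, with compound 1 going against any such reading. The chloro also now has a one-place comparison of its own, since hydrogen in place of chloro on an aromatic carbon raises the number (a 2.4-fold higher number from compound 2 to compound 4 (0.38 log units; beyond the scatter)), which shows the 4-chlorophenyl result of compound 2 against the unsubstituted ring and not only against methoxy-bearing rings. No measurement at hand accounts for any of these steps.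

The compounds shown leave open whether a single methoxy group, as in 4-methoxyphenyl, would stay with phenyl or move towards the trimethoxy result, and whether bromo or fluoro in the place of the chloro would give a similar step. They also leave open whether an amine or a carboxylic acid on this ring would shift the number, and whether these steps would hold on a different core.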